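The source may report more compounds than this note shows. Statements on the series, on what has been measured and on what is new or still open speak of the compounds shown alone.

In an assay on CHO cells for displacement of a labelled ligand from adenosine receptor A3 (Homo sapiens), with a stated time of 60 min (on this read-out higher numbers stand for weaker inhibition and lower numbers for stronger inhibition), compound 1 `O[C@@H]1[C@H](O)[C@@H]2C[C@@H]2[C@H]1n1cnc2c(NC3CCCCCC3)nc(Cl)nc21` gives 560 nM and compound 2 `O[C@@H]1[C@H](O)[C@@H]2C[C@@H]2[C@H]1n1cnc2c(NC3CCCCCCC3)nc(Cl)nc21` gives 1530 nM, while compound 3 `CCC(CC)Nc1nc(Cl)nc2c1ncn2[C@H]1[C@H](O)[C@H](O)[C@@H]2C[C@@H]21` gives 52 nM, the lowest of the three, with the steps of an 11-fold lower number from compound 1 to compound 3 (1.03 log units; beyond the scatter) and a 29-fold lower number from compound 2 to compound 3 (1.47 log units; beyond the scatter) both large. Compound 4 `O[C@@H]1[C@H](O)[C@@H]2C[C@@H]2[C@H]1n1cnc2c(NCc3ccccc3F)nc(Cl)nc21` carries the change (2-fluorobenzyl in place of pentan-3-yl on a nitrogen on an aromatic ring). Among the measured compounds shown here, no measured step swaps in a group with an aromatic ring, so only the general lesson of a 2.7-fold higher number from compound 1 to compound 2 (0.44 log units; beyond the scatter), an 11-fold lower number from compound 1 to compound 3 (1.03 log units; beyond the scatter) and a 29-fold lower number from compound 2 to compound 3 (1.47 log units; beyond the scatter) applies: changing this group moves this assay by large amounts in either direction. For compound 4 the expected step is a 1.2-fold higher number from compound 3 to compound 4 (0.06 log units; within the scatter), and compound 4 is estimated at 60 nM, within 10 nM to 350 nM.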

Compound 4, inhibition constant: 41.5 nM
For compound 4 the middle estimate is 1.4-fold (0.16 log units) above the measured one, and the stated range covers the measured number.
By their numbers in this assay, from the lowest: compounds 4 and 3 (each within the scatter of the next); then compound 1; then compound 2.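

With an aromatic ring on this nitrogen, the number stays level with that of the open-chain pentan-3-yl group, a 1.3-fold lower number from compound 3 to compound 4 (0.10 log units; within the scatter), so this position accepts 2-fluorobenzyl as readily as pentan-3-yl. The ring-bearing group also sits far from the cycloheptyl and cyclooctyl groups, a 13-fold lower number from compound 1 to compound 4 (1.13 log units; beyond the scatter) and a 37-fold lower number from compound 2 to compound 4 (1.57 log units; beyond the scatter), so having a ring in the group does not by itself give a high number. Nothing measured here accounts for these differences. Open still is what the fluorine contributes, which a plain benzyl group would show, and how a longer chain or an amine would behave here.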